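The source may report more compounds than this note shows. Statements on the series, on what has been measured and on what is new or still open speak of the compounds shown alone.

Measured in a functional assay with Oryctolagus cuniculus as the target; on this read-out lower numbers stand for stronger inhibition and higher numbers for weaker inhibition:
- compound 1 `COc1ccc(-c2nc(/N=C(\N)NC3CCCCC3)sc2-c2ccc(OC)cc2)cc1`: > 1000 nM, a limit
- compound 2 `COc1ccc(-c2nc(/N=C(\N)[N+]3(C)CCCCC3)sc2-c2ccc(OC)cc2)cc1`: > 1000 nM, a limit
- compound 3 `CNC(=O)NCc1nc(-c2ccc(OC)cc2)c(-c2ccc(OC)cc2)s1`: 22 nM

Compound 3 is the only one of these with an actual number, and the other two sit at the limit of > 1000 nM in this assay, at which 2 of the 3 values shown sit. The next compound, compound 4 `COc1ccc(-c2nc(C(=O)N(C)C)sc2-c2ccc(OC)cc2)cc1`, has not yet been measured in this assay. It differs from compound 3 as follows: dimethylcarbamoyl in place of ((methylcarbamoyl)amino)methyl on an aromatic carbon. Dimethylcarbamoyl thus takes the place of ((methylcarbamoyl)amino)methyl on an aromatic carbon.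

Two measured steps change the group on an aromatic carbon: an at least 45-fold lower number from compound 1 to compound 3 (1.65 log units; beyond the scatter) and an at least 45-fold lower number from compound 2 to compound 3 (1.65 log units; beyond the scatter). Both are large, so the read-out can move far with this group, at least among these compounds. Neither step involves dimethylcarbamoyl, however, and a step that the two limits leave unreadable from compound 1 to compound 2 adds nothing here. A moderate move toward a higher number, smaller than those two steps, is therefore expected. The estimated change is a 2.7-fold higher number from compound 3 to compound 4 (0.44 log units; beyond the scatter). For compound 4 the expected value is 60 nM, within an estimated range of 10 nM to 400 nM.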

Compound 4, half-maximal inhibitory concentration: < 100 nM
Compound 4: a limit, no number; the forecaster's own chance of this, stated with the estimate: 15%; the middle value does not contradict the limit.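

In this assay compound 4 gives < 100 nM, which is a limit and not a number. Even so, dimethylcarbamoyl on this aromatic carbon, next to the ring nitrogen and next to the ring sulfur, gives an at least 10-fold lower number from compound 2 to compound 4 (1.00 log units; beyond the scatter) and an at least 10-fold lower number from compound 1 to compound 4 (1.00 log units; beyond the scatter), so a low number at this position is not confined to ((methylcarbamoyl)amino)methyl and is kept with a group that has 0 hydrogen-bond donors where that group has 2. The step from compound 3 to dimethylcarbamoyl in compound 4 cannot be read, so these compounds do not rank the two groups.

Where the actual number of compound 4 lies remains open. Also open, as far as these compounds go, is whether a carboxylic acid, a primary amine or a longer chain ending in a urea on this aromatic carbon would keep such low numbers.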